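This account rests on a few compounds, and the source may have more. Where it says the series, first, only, none or still open, it means among the compounds named here.

Measured compounds:
compound 1, `ClCc1ccc(Cn2cnc3c(Cl)ncnc32)cc1`, with 5490 nM in a functional assay on NCI/ADR-RES cells (Homo sapiens) for cytotoxicity, read by sulforhodamine B assay, with a stated time of 48 h; on this read-out lower numbers stand for stronger inhibition of growth and higher numbers for weaker inhibition of growth;
compound 2, `Nc1nc(Cl)c2ncn(Cc3ccc(CCl)cc3)c2n1`, with 26900 nM in this assay;
compound 3, `ClCc1ccccc1Cn1cnc2c(Cl)ncnc21`, with 4670 nM in this assay.

Compound 1 and compound 3 share the same atoms joined differently; the difference between the two cores is not broken down here. Compound 3 has the lowest number of the three, but its gap to compound 1 lies within the scatter, so no order is claimed between them. Compound 2 differs from compound 1 by amino in place of hydrogen on an aromatic carbon, and this step gave a 4.9-fold higher number from compound 1 to compound 2 (0.69 log units; beyond the scatter).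

Compound 4, `Nc1nc(Cl)c2ncn(Cc3ccccc3CCl)c2n1`, has not yet been measured. It differs from compound 3 by amino in place of hydrogen on an aromatic carbon; the place is described word for word as for the earlier pair, so this is the same change. If compound 4 follows the earlier step, its number is expected to be a 4.7-fold higher number from compound 3 to compound 4 (0.67 log units; beyond the scatter), because that change from compound 1 to compound 2 gave a 4.9-fold higher number from compound 1 to compound 2 (0.69 log units; beyond the scatter). Compound 4 is therefore estimated at 22000 nM in this assay, with a range from 9000 nM to 55000 nM.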

Compound 4, concentration for total growth inhibition: 34700 nM
Beside the measured number, compound 4's estimate is 1.6-fold (0.20 log units) below it, within the range that was stated.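

In this assay, amino in place of hydrogen on an aromatic carbon gave a 7.4-fold higher number from compound 3 to compound 4 (0.87 log units; beyond the scatter), which means weaker inhibition of growth. Set beside the earlier step, the change carried over from one core to the other in direction and, within the scatter, in size: the same change on two cores in this assay, a 4.9-fold higher number (0.69 log units; beyond the scatter) from compound 1 to compound 2 and a 7.4-fold higher number (0.87 log units; beyond the scatter) from compound 3 to compound 4, 1.5-fold (0.18 log units) apart, within the scatter of two such steps. Within the data shown here, this rests on only two pairs, in one cell line and with one read-out, so it does not show that the step would hold on any other core, and it does not say why the number rises.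

The compounds shown carry only hydrogen or amino at this place, so it remains open how a methylamino, hydroxyl or methyl group there would compare. As far as these compounds go, all of them also keep the chloromethyl group, and it is unknown whether the step would hold with a hydroxymethyl group in its place or with an amine in place of the chloro group on the ring.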